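Removing the halogens from the aryl group on the piperazine

This account rests on a few compounds, and the source may have more. Where it says the series, first, only, none or still open, it means among the compounds named here.

Compound 1 `CCCn1c(=O)[nH]c2nc(-c3ccc(S(=O)(=O)N4CCN(c5ccc(Cl)cc5F)CC4)cc3)[nH]c2c1=O` has the lower of the two measured numbers in an assay on CHO cells for displacement of a labelled ligand from adenosine receptor A3 (Homo sapiens), read by scintillation counting, with a stated time of 45 min, tested at 1 uM, in the presence of a further agent that is not named here (on this read-out lower numbers stand for less inhibition and higher numbers for more inhibition at the one concentration tested (going by the name of the read-out)), where compound 1 gives 14%. Compound 2 `CCCn1c(=O)[nH]c2nc(-c3ccc(S(=O)(=O)N4CCN(Cc5ccc(Br)c(F)c5)CC4)cc3)[nH]c2c1=O` gives 27%, a step of a number 13 percentage points higher from compound 1 to compound 2 (beyond the scatter). Compound 3 `CCCn1c(=O)[nH]c2nc(-c3ccc(S(=O)(=O)N4CCN(c5ccccc5)CC4)cc3)[nH]c2c1=O` differs from compound 1 in one place: phenyl in place of 4-chloro-2-fluorophenyl on an amine nitrogen in a ring. Among the measured compounds shown here, the only measured step replaces the whole aryl group with a benzyl group rather than removing halogens, so it bears only loosely on this change, and no shift beyond the scatter is expected. Compound 3 is therefore estimated at 15%, range 0% to 35%, a step of a number 1 percentage points higher from compound 1 to compound 3 (within the scatter).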

Compound 3, a percentage reported as inhibition, at one concentration (the size of the read-out at that concentration, not a potency): 27%
For compound 3 the middle estimate is 12 percentage points below the measured one; low and high end bracket the measured number.
By their numbers in this assay, from the lowest: compound 1; then compounds 2 and 3 (each within the scatter of the next).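

In this assay, phenyl in place of 4-chloro-2-fluorophenyl on the amine nitrogen in the ring gives a number 13 percentage points higher from compound 1 to compound 3 (beyond the scatter) and so isolates the loss of the chlorine and the fluorine from the aryl group, which the earlier change to a benzyl group could not do. Phenyl in place of 4-bromo-3-fluorobenzyl gives no change at the digits printed from compound 2 to compound 3 (within the scatter) and leaves those two groups unseparated at this position. Nothing available here explains either step. Going by these compounds, whether the chlorine or the fluorine alone accounts for the first step stays open, as does how an unsubstituted benzyl group or a pyridyl ring on this nitrogen would read.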